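Trifluoromethoxy in Place of Nitro on a Chromone Styryl Series

The compounds below may be only part of what the source reports. "The series", "measured", "known", "first", "only" and "open" are said of these compounds alone.

Measured compounds:
compound 1 `COc1cc(OC)c2c(=O)cc(/C=C/c3ccc([N+](=O)[O-])cc3)oc2c1`: 9600 nM
compound 2 `COc1cc(OC)c2c(=O)cc(/C=C/c3ccc(C(F)(F)F)cc3)oc2c1`: 19000 nM
compound 3 `COc1cc(OC)c2c(=O)cc(/C=C/c3ccc(Br)cc3)oc2c1`: a limit only, > 40000 nM

In a functional assay on HeLa cells (Homo sapiens) for antiproliferative activity, read by MTT assay, with a stated time of 12 h (a higher number here means a weaker inhibitor, a lower number a stronger inhibitor), compound 1 gives the lower of the two numbers that are not limits, and its nearest neighbour is compound 2, whose step a 2.0-fold higher number from compound 1 to compound 2 (0.30 log units; within the scatter) stays within the scatter. For compound 3 this assay reports only a limit, (the limit of > 40000 nM in this assay, at which 1 of the 3 values shown sits). Compound 4 `COc1cc(OC)c2c(=O)cc(/C=C/c3ccc(OC(F)(F)F)cc3)oc2c1` is not yet measured; it differs from compound 1 by trifluoromethoxy in place of nitro on an aromatic carbon. Within the data shown here, the steps that bear on it, a 2.0-fold higher number from compound 1 to compound 2 (0.30 log units; within the scatter) and an at least 4.1-fold higher number from compound 1 to compound 3 (0.61 log units; beyond the scatter), both point toward higher numbers when nitro is exchanged, one within and one beyond the scatter. A modest rise is therefore expected, a 2.6-fold higher number from compound 1 to compound 4 (0.42 log units; beyond the scatter). Compound 4 is estimated at 25000 nM, with a range from 10000 nM to 60000 nM.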

Compound 4, half-maximal inhibitory concentration: > 40000 nM
Compound 4: only a limit was reported; the forecaster's own chance of this, stated with the estimate: 30%; middle value at least 1.6-fold (0.20 log units) away from the limit.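

Compound 4 gives only a limit in this assay, the second compound here to do so: the limit of > 40000 nM in this assay, at which 2 of the 4 values shown sit. Placing trifluoromethoxy at this position gives an at least 4.1-fold higher number from compound 1 to compound 4 (0.61 log units; beyond the scatter), and against the trifluoromethyl compound it gives an at least 2.1-fold higher number from compound 2 to compound 4 (0.32 log units; beyond the scatter), so among the four groups shown only nitro and trifluoromethyl give a measured number. The step between the two compounds that report limits cannot be read.

From the compounds shown here alone, how far compound 3 and compound 4 lie beyond their limit stays open. So does whether an amine or a carboxylic acid at this position would give a lower number than nitro.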